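Compound 3 to compound 4: working notes on the amide

This account rests on a few compounds, and the source may have more. Where it says the series, first, only, none or still open, it means among the compounds named here.

- compound 1 `CCn1c(C(=O)NCC#N)ccc1C(CC)(CC)c1ccc(OCCC(O)(CC)CC)c(C)c1` gives > 50000 nM as a limit
- compound 2 `CCn1c(C(=O)N(CCC#N)CCC#N)ccc1C(CC)(CC)c1ccc(OCCC(O)(CC)CC)c(C)c1` gives 37800 nM as a value
- compound 3 `CCn1c(C(=O)Nc2ccc(OC(F)(F)F)cc2)ccc1C(CC)(CC)c1ccc(OCCC(O)(CC)CC)c(C)c1` gives > 50000 nM as a limit

In an ADME assay on L02 cells (Homo sapiens) for antiproliferative activity, read by MTT assay, with a stated time of 48 h (a lower number here means a stronger inhibitor, a higher number a weaker inhibitor), compound 3 stands at > 50000 nM as a limit, not a number. The change to compound 4 `CCC(C)C(NC(=O)c1ccc(C(CC)(CC)c2ccc(OCCC(O)(CC)CC)c(C)c2)n1CC)C(=O)OC` is a group of 9 heavy atoms (7 carbon, 2 oxygen; no ring) in place of a group of 11 heavy atoms (7 carbon, 1 oxygen, 3 fluorine; one six-membered aromatic ring of carbon only), on an amide-type nitrogen and the shared core stays as it is. The steps a step that the two limits leave unreadable from compound 1 to compound 3 and an at least 1.3-fold higher number from compound 2 to compound 3 (0.12 log units; that floor lies within the scatter) bear on it, and neither shows a readable size beyond the scatter. Among the compounds with values here, the series so far stands at the limit of > 50000 nM in this assay, at which 2 of the 3 values shown sit, and offers no sign of a larger move. The expected step is an at least 1.1-fold lower number from compound 3 to compound 4 (0.07 log units; that floor lies within the scatter) in this assay and none beyond the scatter is expected. For compound 4 the estimated value is 42000 nM with an expected range from 20000 nM to 80000 nM in this series.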

Compound 4, half-maximal inhibitory concentration: > 50000 nM
Compound 4: no number, only a limit (the forecaster's own chance of this, stated with the estimate: 55%); middle value at least 1.1-fold (0.07 log units) from the limit.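

In this assay compound 4 gives > 50000 nM, a limit and not a number. Within the data shown here, with the group of 9 heavy atoms on the amide-type nitrogen, the steps from compound 1 and from compound 3 cannot be read, and the one readable step is an at least 1.3-fold higher number from compound 2 to compound 4 (0.12 log units; that floor lies within the scatter). A non-aromatic group with no ring at this place thus ends at the same limit as the 4-(trifluoromethoxy)phenyl of compound 3: the limit of > 50000 nM in this assay, at which 3 of the 4 values shown sit.

On these data alone, whether a carboxylic acid or an amine on this nitrogen would give a number in this assay stays open. As far as these compounds go, the size of any difference among compound 1, compound 3 and compound 4 also stays open.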